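The source may report more compounds than this note shows. Statements on the series, on what has been measured and on what is new or still open speak of the compounds shown alone.

Compound 1 `CC(C)[C@H]1C(O)=C(C2=NS(=O)(=O)c3c(OCC(N)=O)cccc32)C(=O)N1Cc1ccccc1`. In an in vitro ADME assay on microsomes from liver (Homo sapiens) for metabolic stability (a lower number here means that the compound disappears faster, a higher number that the compound lasts longer), compound 1 gives > 1 h, which is a limit of the assay and not a number.
Compound 2 `CC(C)[C@H]1C(O)=C(C2=NS(=O)(=O)c3c(OCC#N)cccc32)C(=O)N1Cc1ccccc1`. In this assay compound 2 gives > 1 h, again a limit.
Compound 3 `CC(C)(C)[C@H]1C(O)=C(C2=NS(=O)(=O)c3c(OCC(N)=O)cccc32)C(=O)N1Cc1ccc(F)c(Cl)c1`. In this assay compound 3 gives > 1 h, also a limit.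

From compound 1 to compound 2 the change is cyano in place of carbamoyl on a saturated chain carbon bound to an oxygen on an aromatic ring, and its step in this assay is a step that the two limits leave unreadable from compound 1 to compound 2. The difference between the core of compound 1 and the core of compound 3 is not broken down here. Compound 4 `CC(C)(C)[C@H]1C(O)=C(C2=NS(=O)(=O)c3c(OCC#N)cccc32)C(=O)N1Cc1ccc(F)c(Cl)c1` is not yet measured; it differs from compound 3 by cyano in place of carbamoyl on a saturated chain carbon bound to an oxygen on an aromatic ring, the same change at the same place. Because (the limit of > 1 h in this assay, at which 3 of the 3 values shown sit), the step from compound 1 to compound 2 cannot be read. For compound 4 the expected step is a step that the limit leaves unreadable from compound 3 to compound 4, resting on the limits shown for compound 3 and compound 2. Compound 4 is estimated at 1.5 h, between 0.7 h and 4 h.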

Compound 4, half-life: > 1 h
Compound 4: a limit, no number; the forecaster's own chance of this, stated with the estimate: 80%; the middle value does not contradict the limit.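

The step from compound 3 to compound 4 cannot be read, because both values are limits and not numbers: the limit of > 1 h in this assay, at which 4 of the 4 values shown sit.

The compounds shown leave open how long each one actually lasts in this assay, and whether cyano in place of carbamoyl changes that at all.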